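This account rests on a few compounds, and the source may have more. Where it says the series, first, only, none or still open, it means among the compounds named here.

Measured in a functional assay on NCI-H1993 cells (Homo sapiens) for inhibition, read by CCK-8 assay, with a stated time of 72 h; on this read-out higher numbers stand for weaker inhibition and lower numbers for stronger inhibition:
compound 1, `CC(c1ccc2ncc(-c3ccc(F)cc3)cc2c1)n1nnc2ncc(-c3ccncc3)nc21`, gives 8.7 nM;
compound 2, `CC(c1ccc2ncc(-c3cnn(C)c3)cc2c1)n1nnc2ncc(-c3ccc(C(N)=O)c(F)c3)nc21`, gives 0.9 nM;
compound 3, `CC(c1ccc2ncc(-c3cnn(C)c3)cc2c1)n1nnc2ncc(-c3ccncc3)nc21`, gives 0.9 nM.

Compound 2 stands level with compound 3 at the digits shown, the two together holding the lowest numbers of the three, while compound 1 lies furthest away, as the step of a 9.7-fold lower number from compound 1 to compound 3 (0.99 log units; beyond the scatter) shows for its match compound 3. Compound 4, `CC(c1cc2cc(-c3cnn(C)c3)cnc2cc1F)n1nnc2ncc(-c3ccc(C(N)=O)c(F)c3)nc21`, differs from compound 2 by fluoro in place of hydrogen on an aromatic carbon, on a six-membered aromatic ring of carbon only within a fused system of two rings, ortho to a large group. Neither measured step touches that ring: a 9.7-fold lower number from compound 1 to compound 3 (0.99 log units; beyond the scatter) exchanges a group elsewhere on the shared core, and no change at the digits printed from compound 2 to compound 3 (within the scatter) exchanges the group at the other end. Going by the values given here, no step therefore speaks to this change, and no shift beyond the scatter is expected. Compound 4 is estimated at 1.2 nM (range 0.4 nM to 4 nM), an expected step of a 1.3-fold higher number from compound 2 to compound 4 (0.12 log units; within the scatter).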

Compound 4, half-maximal inhibitory concentration: 0.9 nM
Compound 4: middle estimate off by 1.3-fold (0.12 log units), on the high side; low and high end bracket the measured number.
By their numbers in this assay, from the lowest: compounds 2, 3 and 4 (each within the scatter of the next); then compound 1.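

In this assay, going by these compounds alone, fluoro in place of hydrogen gives no change at the digits printed from compound 2 to compound 4 (within the scatter) on this six-membered aromatic ring of carbon only, the first reading at a position that no earlier step touched. This carbon, ortho to a large group, therefore takes a single fluorine with no shift beyond the scatter. No evidence bears on this result. From the compounds shown here alone, whether a larger group on the same carbon, such as methoxy or an amine, would leave the number level stays open. So does whether fluoro would behave alike with the pyridin-4-yl group of compound 3.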